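The compounds below may be only part of what the source reports. "The series", "measured", "known", "first", "only" and "open" are said of these compounds alone.

Compound 1 `COc1cc(NC(=O)NNc2cc(-c3ccccc3)c3cnn(C)c3n2)cc(Cl)n1`: 3640 nM
Compound 2 `COc1ccc(-c2cc(NNC(=O)Nc3cc(Cl)nc(OC)c3)nc3c2cnn3C)cc1`: 1980 nM
Compound 3 `COc1cc(NC(=O)NNc2cc(-c3ccc(F)cc3)c3cnn(C)c3n2)cc(Cl)n1`: 1650 nM

All three were tested in an assay on isolated protein for binding affinity to sphingosine 1-phosphate receptor 2 (Homo sapiens), read by surface plasmon resonance; on this read-out higher numbers stand for weaker binding and lower numbers for tighter binding. Compound 3 has the lowest of the three numbers: the step of a 2.2-fold lower number from compound 1 to compound 3 (0.34 log units; beyond the scatter) lies beyond the scatter, while the step of a 1.2-fold lower number from compound 2 to compound 3 (0.08 log units; within the scatter) lies within it, so compound 2 and compound 3 cannot be told apart. Compound 4 `CCCCOc1cc(NC(=O)NNc2cc(-c3ccc(F)cc3)c3cnn(C)c3n2)cc(Cl)n1` differs from compound 3 in one place: propyl in place of hydrogen on a saturated chain carbon bound to an oxygen on an aromatic ring. For the measured compounds named here, none of the measured steps touches this place; the steps of a 1.8-fold lower number from compound 1 to compound 2 (0.26 log units; within the scatter), a 2.2-fold lower number from compound 1 to compound 3 (0.34 log units; beyond the scatter) and a 1.2-fold lower number from compound 2 to compound 3 (0.08 log units; within the scatter) all swapped a substituent on an aromatic carbon elsewhere in the molecule. There is thus no measured guide for this change, and no step beyond the scatter is expected; the estimated step is a 1.0-fold higher number from compound 3 to compound 4 (0.01 log units; within the scatter). Compound 4 is therefore estimated at 1700 nM, within a range from 600 nM to 5000 nM.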

Compound 4, dissociation constant: 2650 nM
Estimate against measurement, compound 4: 1.6-fold (0.19 log units) below; the range from low to high includes it.
By their numbers in this assay, from the lowest: compounds 3, 2, 4 and 1 (each within the scatter of the next, the first and the last beyond it).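

For the compounds shown here, compound 3 and compound 4 differ only in methoxy versus butoxy, and this pair gives the first view of a change at the saturated chain carbon bound to an oxygen on an aromatic ring (a 1.6-fold higher number from compound 3 to compound 4 (0.21 log units; within the scatter)). The much longer chain therefore leaves the number within the scatter, so binding here shows no measurable sensitivity to this extension. No measurement shown accounts for this result.

As far as these compounds go, whether a chain ending in an amine or a carboxylic acid would behave the same remains open. So does whether butoxy would read alike without the fluoro group.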